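Removing one methoxy from the trimethoxyphenyl sulfonamide

The source may report more compounds than this note shows. Statements on the series, on what has been measured and on what is new or still open speak of the compounds shown alone.

Compound 1 `COc1cc(NS(=O)(=O)c2ccc(N3CCNC3=O)cc2)cc(OC)c1OC` carries three methoxy groups on the aniline ring of a sulfonamide joined to a phenyl that bears an imidazolidinone. In a functional assay on CHO cells (Homo sapiens) for antiproliferative activity against CHO (Cricetulus griseus), read by sulforhodamine B assay, with a stated time of 48 h (on this read-out lower numbers stand for stronger inhibition and higher numbers for weaker inhibition), compound 1 gives 190 nM, the lowest number of the three measured here. Compound 2 `CCc1cccc(NS(=O)(=O)c2ccc(N3CCNC3=O)cc2)c1` swaps the trimethoxy ring for an ethylphenyl ring, and in this assay compound 2 gives 230 nM, a number within the scatter of compound 1, so the two cannot be told apart. Compound 3 `O=C1NCCN1c1ccc(S(=O)(=O)Nc2ccc3[nH]ccc3c2)cc1` places an indole on the sulfonamide nitrogen instead, and in this assay compound 3 gives 1310 nM, a gap to compound 1 that lies beyond the scatter.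

Compound 4 `COc1cc(NS(=O)(=O)c2ccc(N3CCNC3=O)cc2)cc(OC)c1` differs from compound 1 in one place: hydrogen in place of methoxy on an aromatic carbon. Among the measured compounds shown here, no measured pair in this set isolates such a change, so the size of the step rests on judgment alone. The account expects compound 4 to be somewhat weaker than compound 1, with the step from compound 1 to compound 4 estimated at a 2.9-fold higher number from compound 1 to compound 4 (0.46 log units; beyond the scatter) in this assay, a loss that may reach just beyond the scatter. For compound 4 in this assay the expected value is 550 nM, within a range from 180 nM to 1800 nM.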

Compound 4, half-maximal inhibitory concentration: 330 nM
The estimate for compound 4 lay 1.7-fold (0.22 log units) above the measured number, within the range that was stated.
By their numbers in this assay, from the lowest: compounds 1, 2 and 4 (each within the scatter of the next); then compound 3.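

Among the compounds shown here, this is the first pair in the set that differs in one place, and it isolates the methoxy on the aromatic carbon that is ortho to two methoxy groups and para to a large group. In this assay, hydrogen in place of that methoxy gives a 1.7-fold higher number from compound 1 to compound 4 (0.24 log units; within the scatter), so compound 1 and compound 4 cannot be told apart, and this methoxy can be lost, along with its two heavy atoms and one hydrogen-bond acceptor, without a difference this assay can resolve. Nothing available here speaks to why the number holds when the group is removed.

From the compounds shown here alone, it remains open whether this position would tolerate other groups equally well, such as a hydroxyl, an amine, a fluorine or a longer chain like ethoxy, or whether some of these would move the number beyond the scatter in either direction. Also open, going by these compounds, is what would follow if hydrogen replaced one or both of the two methoxy groups still present on compound 4.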